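Phenyl Substituent Changes on the Aromatic Nitrogen

This account rests on a few compounds, and the source may have more. Where it says the series, first, only, none or still open, it means among the compounds named here.

Compound 3 `CC1(C)[C@H]2CC[C@]1(C)N(Cc1cn(-c3ccccc3Br)nn1)C(=O)C2` gives 150 nM in a functional assay on HepG2 cells (Homo sapiens) for inhibition, read by MTT assay, with a stated time of 24 h (on this read-out higher numbers stand for weaker inhibition and lower numbers for stronger inhibition), the highest of the three numbers, yet within the scatter of compound 1 `CC1(C)[C@H]2CC[C@]1(C)N(Cc1cn(-c3ccc(Cl)cc3)nn1)C(=O)C2` at 90 nM and of compound 2 `COc1ccccc1-n1cc(CN2C(=O)C[C@@H]3CC[C@@]2(C)C3(C)C)nn1` at 110 nM. Compound 4 `CC1(C)[C@H]2CC[C@]1(C)N(Cc1cn(-c3cccc(O)c3)nn1)C(=O)C2` differs from compound 3 by 3-hydroxyphenyl in place of 2-bromophenyl on an aromatic nitrogen. For the measured compounds named here, the steps that bear on this are a 1.7-fold higher number from compound 1 to compound 3 (0.22 log units; within the scatter) and a 1.4-fold higher number from compound 2 to compound 3 (0.13 log units; within the scatter), both within the scatter, as is a 1.2-fold higher number from compound 1 to compound 2 (0.09 log units; within the scatter); every change so far on this phenyl has left the number essentially unmoved. From the compounds shown here alone, a hydroxy group on this phenyl is untested, so the expectation rests on these steps alone. Compound 4 is therefore expected to give 130 nM, with a range of 60 nM to 300 nM. The expected step of a 1.2-fold lower number from compound 3 to compound 4 (0.06 log units; within the scatter) is estimated to stay within the scatter.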

Compound 4, half-maximal inhibitory concentration: 70 nM
Estimate against measurement, compound 4: 1.9-fold (0.27 log units) above; the measured number falls inside the stated range.
By their numbers in this assay, from the lowest: compounds 4, 1, 2 and 3 (each within the scatter of the next, the first and the last beyond it).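

In this assay, for the compounds shown here, the 3-hydroxyphenyl gives the first step on this phenyl that passes the scatter (a 2.1-fold lower number from compound 3 to compound 4 (0.33 log units; beyond the scatter)), but only against the 2-bromophenyl. Against the other two groups the steps stay within the scatter (a 1.6-fold lower number from compound 2 to compound 4 (0.20 log units; within the scatter); a 1.3-fold lower number from compound 1 to compound 4 (0.11 log units; within the scatter)), so a phenyl carrying a hydrogen-bond donor keeps the number in the same range without a clear gain. No measured evidence bears on what lies behind the step.

Whether the entering hydroxy group or the departing bromo accounts for that step stays open. So does whether an amine or a carboxylic acid on this phenyl would keep the number in this range.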